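Oral exposure in the series: from compound 2 to compound 3

The compounds below may be only part of what the source reports. "The series", "measured", "known", "first", "only" and "open" are said of these compounds alone.

Measured so far:
compound 1, `Nc1ncc(-c2nc3ccccc3s2)c(N[C@@H]2C[C@H](CO)[C@@H](O)[C@H]2O)n1` — 149 ng.h/mL
compound 2, `Cc1nc(NCC(C)C)nc(N[C@@H]2C[C@H](CO)[C@@H](O)[C@H]2O)c1-c1nc2ccccc2s1` — 1020 ng.h/mL

In an ADME assay on the whole organism (plasma) for pharmacokinetics, with Rattus norvegicus as the target, with a stated time of 6 h, at a dose of 10 mg/kg by the oral route (a lower number here means less compound in the circulation, a higher number more compound in the circulation at the dose given), compound 2 gives 1020 ng.h/mL, the higher of the two numbers; the gap to compound 1 lies beyond the scatter. Compound 3 is `Cc1nc(NCCC(F)(F)F)nc(N[C@@H]2C[C@H](CO)[C@@H](O)[C@H]2O)c1-c1nc2ccccc2s1`. It differs from compound 2 in one place: 2,2,2-trifluoroethyl in place of isopropyl on a saturated chain carbon bound to a nitrogen on an aromatic ring. Among the measured compounds shown here, no two measured compounds differ in a single place, so the series gives no measured step of this kind to lean on. Compound 3 is expected to give about 800 ng.h/mL, with a range of 300 ng.h/mL to 2500 ng.h/mL. The expected step of a 1.3-fold lower number from compound 2 to compound 3 (0.11 log units; within the scatter) is taken to be none beyond the scatter.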

Compound 3, area under the concentration-time curve: 2560 ng.h/mL
The estimate for compound 3 lay 3.2-fold (0.51 log units) below the measured number; the measured number lies above the stated range.
By their numbers in this assay, from the lowest: compound 1; then compound 2; then compound 3.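

In this assay, among the compounds shown here, the change of isopropyl to 2,2,2-trifluoroethyl on a saturated chain carbon bound to a nitrogen on an aromatic ring gives a 2.5-fold higher number from compound 2 to compound 3 (0.40 log units; beyond the scatter), the first single-place step. Oral exposure therefore responds to this position alone, with the core unchanged. Nothing measured here accounts for the rise.

Going by these compounds, whether the gain needs the fluorine atoms at all stays open, and a plain n-butyl chain at this place would separate the two readings. How a longer fluorinated chain or a cyclopropylmethyl group would compare is equally unknown.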